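The source may report more compounds than this note shows. Statements on the series, on what has been measured and on what is new or still open speak of the compounds shown alone.

Working notes on the series. All three measured compounds share the same bicyclic ketone core, linked through a sulfonylmethyl group to a piperazine whose far nitrogen bears an aryl group. Compound 1 `CC1CN(S(=O)(=O)C[C@]23CC[C@H](CC2=O)C3(C)C)CCN1c1ccc(C(F)(F)F)cn1` carries a methyl on a saturated ring carbon of the piperazine and a trifluoromethyl on its pyridin-2-yl group; in a functional assay on CHO-K1 cells for antagonist activity at C-X-C chemokine receptor type 3 (Homo sapiens), read by FLIPR and calcium flux (a lower number here means a stronger inhibitor, a higher number a weaker inhibitor), compound 1 gives 316 nM. Compound 3 `CC1(C)[C@@H]2CC[C@@]1(CS(=O)(=O)N1CCN(c3ccc(C(F)(F)F)cn3)C(c3ccccc3)C1)C(=O)C2` in this assay gives only a limit, > 31600 nM. Going by the values given here, the one single-point step, an at least 100-fold higher number from compound 1 to compound 3 (2.00 log units; beyond the scatter), is large. Compound 2 `CC1(C)[C@@H]2CC[C@@]1(CS(=O)(=O)N1CCN(c3ccccn3)CC1)C(=O)C2` in this assay likewise returns only a limit, > 31600 nM. Compound 2 therefore stands at the limit of > 31600 nM in this assay, at which 2 of the 3 values shown sit, with no number of its own.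

Compound 4 `CC1(C)[C@@H]2CC[C@@]1(CS(=O)(=O)N1CCN(c3ncc(C(F)(F)F)cn3)CC1)C(=O)C2` differs from compound 2 by 5-(trifluoromethyl)pyrimidin-2-yl in place of pyridin-2-yl on an amine nitrogen in a ring. Among the compounds with values here, no measured step touches the aryl group itself: the step from compound 1 to compound 3 concerns a saturated ring carbon and bears on this change only indirectly. Within the data shown here, compound 1 and compound 2 differ in two places, yet compound 1, which carries a trifluoromethyl on its aryl group, is the sole compound with a numerical value. On that basis a move toward a lower number is expected for compound 4. Compound 4 is estimated in this assay at 1500 nM, with a range from 250 nM to 12000 nM. This corresponds to an expected at least 21-fold lower number from compound 2 to compound 4 (1.32 log units; beyond the scatter).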

Compound 4, half-maximal inhibitory concentration: 316 nM
Compound 4: middle estimate off by 4.7-fold (0.68 log units), on the high side; the measured number falls inside the stated range.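

In this assay, replacing pyridin-2-yl with 5-(trifluoromethyl)pyrimidin-2-yl on an amine nitrogen in a ring gives an at least 100-fold lower number from compound 2 to compound 4 (2.00 log units; beyond the scatter) and brings a number out of the limit through a change in the aryl group alone. Going by these compounds alone, the earlier compounds offered only one single-place step, on a saturated ring carbon of the piperazine, so they left the effect of the aryl group to inference from a comparison of compounds differing in two places; this step now shows directly that the aryl group on this nitrogen is a place where one change can decide whether a measurable value appears. Compound 2 gives only a limit, so the step marks a minimum size and not a measured one: the limit of > 31600 nM in this assay, at which 2 of the 4 values shown sit.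

The change alters two things at once, adding a trifluoromethyl group and a second ring nitrogen, and no pair among the compounds shown separates the two. Also open, as far as these compounds go, is whether a chlorine or a nitrile in place of the trifluoromethyl group on this aryl ring would give a number of the same order in this setting.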